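A few compounds are considered here, and "the series" means these few. Any claim that something is new, unique, unknown or untested is made for them only; others in the source may bear on it.

Three compounds sharing one core, each carrying a trimethoxyphenyl group, have been tested in a functional assay on HepG2 cells (Homo sapiens) for antiproliferative activity, read by MTT assay, with a stated time of 48 h; a lower number here means a stronger inhibitor, a higher number a weaker inhibitor. Compound 1 `COc1cc(-c2nnc(SCC(=O)c3ccc(C(F)(F)F)cc3)n2N)cc(OC)c1OC` reaches only a limit of the assay there, > 100000 nM. Compound 2 `COc1cc(-c2nnc(SCC(=O)c3ccccc3F)n2N)cc(OC)c1OC` gives 22600 nM in this assay. Compound 3 `COc1cc(-c2nnc(SCC(=O)Nc3ccccc3C)n2N)cc(OC)c1OC`, the amide of the set, likewise reaches only a limit, > 100000 nM. Compound 3 therefore stands at the weak end of what the numbers show, sitting at the same limit as compound 1 (the limit of > 100000 nM in this assay, at which 2 of the 3 values shown sit); the step from the ketone to the amide, an at least 4.4-fold higher number from compound 2 to compound 3 (0.64 log units; beyond the scatter), shows the amide losing activity, while a step that the two limits leave unreadable from compound 1 to compound 3 cannot be read between two limits. Compound 4 `COc1cccc(NC(=O)CSc2nnc(-c3cc(OC)c(OC)c(OC)c3)n2N)c1` differs from compound 3 in one place: 3-methoxyphenyl in place of 2-methylphenyl on an amide-type nitrogen. Going by the values given here, no measured step alters the aryl group on the amide nitrogen; the only measured aryl exchange, an at least 4.4-fold lower number from compound 1 to compound 2 (0.64 log units; beyond the scatter), sits on a ketone carbon and cannot be carried over. Compound 4 is therefore expected to stay near the limit, with a number no higher from compound 3 to compound 4 (the limit leaves the size open) as the expected step. The estimated value for compound 4 is 100000 nM, within a range of 30000 nM to 300000 nM.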

Compound 4, half-maximal inhibitory concentration: > 100000 nM
Compound 4: a limit, no number; the forecaster's own chance of this, stated with the estimate: 80%; the middle value lies on the limit itself.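

In this assay compound 4 gives > 100000 nM, which is a limit and not a number, so a second aryl group on the amide-type nitrogen, 3-methoxyphenyl in place of 2-methylphenyl, still yields no readable value. The gap between the amide series and the 2-fluorophenyl ketone holds for this amide too, with an at least 4.4-fold higher number from compound 2 to compound 4 (0.64 log units; beyond the scatter), so the loss seen earlier is not confined to the 2-methylphenyl group, while the steps from the two other limit compounds to compound 4 cannot be read. Compound 1, compound 3 and compound 4 now share one limit: the limit of > 100000 nM in this assay, at which 3 of the 4 values shown sit.

From the compounds shown here alone, whether any amide on this core can give a readable number stays open, for instance with a cyclohexyl group or a benzoic acid on the nitrogen. Going by these compounds, whether compound 3 and compound 4 differ at all also stays open, as both values are limits.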